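Changing the Benzyl Group: Methoxy Gives Way to Nitrile

A few compounds are considered here, and "the series" means these few. Any claim that something is new, unique, unknown or untested is made for them only; others in the source may bear on it.

Compound 1, `O=c1ccoc2cc(OCc3cn(Cc4ccccc4Br)nn3)ccc12`, gives in a functional assay on A549 cells (Homo sapiens) for cytotoxicity, read by MTT assay, with a stated time of 48 h (on this read-out higher numbers stand for weaker inhibition and lower numbers for stronger inhibition), only the assay limit > 100000 nM.
Compound 2, `O=c1ccoc2cc(OCc3cn(Cc4ccc(F)cc4)nn3)ccc12`, also gives only a limit, > 100000 nM, in this assay.
Compound 3, `COc1ccc(Cn2cc(COc3ccc4c(=O)ccoc4c3)nn2)cc1`, gives 16500 nM in this assay.

Among the measured compounds shown here, compound 3 is thus the one compound with a true number; the other two sit at the limit of > 100000 nM in this assay, at which 2 of the 3 values shown sit. Compound 4, `N#Cc1cccc(Cn2cc(COc3ccc4c(=O)ccoc4c3)nn2)c1`, carries 3-cyanophenyl in place of 4-methoxyphenyl on a saturated chain carbon bound to an aromatic nitrogen. For the measured compounds named here, the steps that bear on this are an at least 6.0-fold lower number from compound 1 to compound 3 (0.78 log units; beyond the scatter) and an at least 6.0-fold lower number from compound 2 to compound 3 (0.78 log units; beyond the scatter): both changes away from the 4-methoxyphenyl group were tied to a limit rather than a number. A move back toward a higher number, possibly again a limit, is therefore expected for compound 4 in this assay, with a 3.0-fold higher number from compound 3 to compound 4 (0.48 log units; beyond the scatter) as the estimated step. Compound 4 is estimated at 50000 nM, between 12000 nM and 200000 nM.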

Compound 4, half-maximal inhibitory concentration: 14300 nM
Estimate against measurement, compound 4: 3.5-fold (0.54 log units) above, and the stated range covers the measured number.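

In this assay, 3-cyanophenyl in place of 4-methoxyphenyl gives a 1.2-fold lower number from compound 3 to compound 4 (0.06 log units; within the scatter), so a measured number at this position does not depend on the 4-methoxyphenyl group alone. Compound 4 also separates from the other two benzyl variants, with an at least 6.9-fold lower number from compound 2 to compound 4 (0.84 log units; beyond the scatter) and an at least 6.9-fold lower number from compound 1 to compound 4 (0.84 log units; beyond the scatter). Compound 1 and compound 2 stay at a limit: the limit of > 100000 nM in this assay, at which 2 of the 4 values shown sit.

Still open, as far as these compounds go, is whether an amine or a carboxylic acid on the phenyl ring would keep a measured number. From the compounds shown here alone, a longer chain in place of the saturated chain carbon is equally open.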